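The compounds below may be only part of what the source reports. "The series", "measured", "known", "first", "only" and "open" are said of these compounds alone.

Compound 2 `C/C(=N\Nc1nc(-c2ccc(Cl)cc2)cs1)c1sc(C)nc1C` is the reference point for this step. In a toxicity assay on HCT-116 cells (Homo sapiens) for cytotoxicity, read by MTT assay (on this read-out lower numbers stand for stronger inhibition of growth and higher numbers for weaker inhibition of growth), compound 2 gives > 100 ug/mL, which is a limit of the assay and not a number. Compound 1 `C/C(=N\Nc1nc(-c2ccc(F)cc2)cs1)c1sc(C)nc1C` carries fluoro where compound 2 carries chloro. In this assay compound 1 gives > 100 ug/mL, again a limit rather than a number. The step that the two limits leave unreadable from compound 1 to compound 2 therefore cannot be sized; both measured values sit at the limit of > 100 ug/mL in this assay, at which 2 of the 2 values shown sit.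

Compound 3 `C/C(=N\Nc1nc(-c2ccc(C)cc2)cs1)c1sc(C)nc1C` differs from compound 2 in one place: methyl in place of chloro on an aromatic carbon. Among the compounds with values here, the only measured step that bears on an exchange at this position, a step that the two limits leave unreadable from compound 1 to compound 2, is left unreadable by its two limits, so no resolved change for any substituent on this ring is available. Nothing in the measured values points to a step beyond the scatter in this assay, and the step expected for this exchange is a step that the limit leaves unreadable from compound 2 to compound 3, with a further limit the most likely outcome. Compound 3 is expected to give 150 ug/mL in this assay, within an estimated range of 50 ug/mL to 450 ug/mL.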

Compound 3, concentration for 50% growth inhibition: > 100 ug/mL
Compound 3: a limit, no number (the forecaster's own chance of this, stated with the estimate: 85%); the middle value is on the limit's open side.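

The steps among compound 1, compound 2 and compound 3 cannot be read in this assay, as each value is a limit and not a number: the limit of > 100 ug/mL in this assay, at which 3 of the 3 values shown sit.

The compounds shown leave open whether fluoro, chloro and methyl differ at all in this assay, and which change, if any, would give a value inside the measurable range.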